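Moving a methoxy group around the ring in compound 4

This account rests on a few compounds, and the source may have more. Where it says the series, first, only, none or still open, it means among the compounds named here.

Measured so far in an assay on isolated protein for inhibition of aldehyde dehydrogenase 1A1 (Homo sapiens); on this read-out higher numbers stand for weaker inhibition and lower numbers for stronger inhibition:
Compound 1 `CC(Sc1nc2c(cnn2C)c(=O)n1-c1ccc(CO)cc1)c1ccccc1`: 600 nM
Compound 2 `CC(Sc1nc2c(cnn2C)c(=O)n1-c1ccccc1)c1ccncc1`: 451 nM
Compound 3 `COc1ccc(C(C)Sc2nc3c(cnn3C)c(=O)n2-c2ccccc2)cc1`: 352 nM

Compound 3 gives the lowest of the three numbers, but its gap to compound 2 and to compound 1 is within the scatter, so the three compounds cannot be told apart on these numbers. Going by the values given here, the only single-place step recorded, a 1.3-fold lower number from compound 2 to compound 3 (0.11 log units; within the scatter), shows that swapping the pyridin-4-yl for a 4-methoxyphenyl left the read-out essentially unchanged.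

Compound 4 `COc1ccccc1C(C)Sc1nc2c(cnn2C)c(=O)n1-c1ccccc1` keeps every atom of compound 3 and only moves the methoxy group: 2-methoxyphenyl in place of 4-methoxyphenyl on a saturated chain carbon bound to a saturated chain carbon and a sulfur. Among the compounds with values here, no measured pair shows this kind of change, so the one recorded step offers no direct guide. With nothing to suggest otherwise, the expected step of a 1.1-fold higher number from compound 3 to compound 4 (0.06 log units; within the scatter) is none beyond the scatter. Compound 4 is therefore estimated at 400 nM in this assay, with a range from 150 nM to 1100 nM.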

Compound 4, half-maximal inhibitory concentration: 445 nM
For compound 4 the middle estimate is 1.1-fold (0.05 log units) below the measured one, and the stated range covers the measured number.
By their numbers in this assay, from the lowest: compounds 3, 4, 2 and 1 (each within the scatter of the next).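

In this assay, moving the methoxy group to give 2-methoxyphenyl in place of 4-methoxyphenyl produces a 1.3-fold higher number from compound 3 to compound 4 (0.10 log units; within the scatter), so the two placements on this ring cannot be told apart. Compared with the pyridin-4-yl group at the same place, the 2-methoxyphenyl group gives a 1.0-fold lower number from compound 2 to compound 4 (0.01 log units; within the scatter), so these two groups cannot be told apart either. No independent measurement is available to explain these results.

From the compounds shown here alone, all the steps at this place lie within the scatter, so it remains open whether any change here can shift the read-out measurably. A carboxylic acid or an amine on this ring, or a longer chain in place of the ring, could test how much this place tolerates.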